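A few compounds are considered here, and "the series" means these few. Any claim that something is new, unique, unknown or untested is made for them only; others in the source may bear on it.

Measured so far:
Compound 1 `O=C(Nc1ncc(Cc2ccc(F)cc2)s1)C1CCCCC1`: > 50000 nM in an ADME assay on HepG2 2.2.15 cells (Homo sapiens) for cytotoxicity; on this read-out higher numbers stand for lower toxicity in this test and lower numbers for higher toxicity in this test — a limit of the test, not a number
Compound 2 `O=C(Nc1ncc(C(OCc2ccc(Cl)cc2)c2ccccc2)s1)c1cccs1`: "not toxic" (no number reported) in this assay

Compound 2 thus stands without a single number in this assay; its result is only a report of no toxicity. Compound 1 sits at the limit of > 50000 nM in this assay, at which 1 of the 2 values shown sits. Compound 3 `O=C(Nc1ncc(C(OCc2ccc3ccccc3c2)c2ccccc2)s1)c1cccs1` differs from compound 2 by naphthalen-2-yl in place of 4-chlorophenyl on a saturated chain carbon bound to an oxygen on a saturated carbon. For the measured compounds named here, no measured step exists for this change, so the expectation rests on the two results at hand, which both report no toxicity; no shift beyond the usual scatter is expected in this assay. Compound 3 is therefore estimated at 60000 nM, with a range of 20000 nM to 200000 nM, and most likely reported again only as a limit.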

Compound 3, half-maximal cytotoxic concentration: "not toxic" (no number reported)
Nothing numeric was reported for compound 3; no gap can be computed for the estimate.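

Compound 2 and compound 3 are both reported only as not toxic in this assay, and no step can be read between them. The compounds shown leave open at what concentration, if any, either becomes toxic to these cells.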